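This account rests on a few compounds, and the source may have more. Where it says the series, first, only, none or still open, it means among the compounds named here.

Values in an ADME assay on microsomes from liver (Rattus norvegicus) for metabolic stability; on this read-out higher numbers stand for a longer-lived compound and lower numbers for a shorter-lived compound:
- Compound 1 `CC(C)C(Nc1nnc[nH]1)c1ccc(-c2ccc3cccc(F)c3c2)[nH]c1=O`: 1.29 h
- Compound 2 `CC(C)C(c1nnc[nH]1)c1ccc(-c2ccc3cccc(F)c3c2)[nH]c1=O`: 0.552 h
- Compound 3 `CC(C)C(c1cnc(N)s1)c1ccc(-c2ccc3cccc(F)c3c2)[nH]c1=O`: 0.0983 h

Compound 3 stands lowest of the three, with 0.0983 h. Compound 4 `CC(C)NC(=O)CC(c1ccc(-c2ccc3cccc(F)c3c2)[nH]c1=O)C(C)C` differs from it in one place: (isopropylcarbamoyl)methyl in place of 2-amino-1,3-thiazol-5-yl on a saturated chain carbon bound to an aromatic carbon and a saturated chain carbon. The two measured steps that bring in the 2-amino-1,3-thiazol-5-yl group are a 5.6-fold lower number from compound 2 to compound 3 (0.75 log units; beyond the scatter), which is modest, and a 13-fold lower number from compound 1 to compound 3 (1.12 log units; beyond the scatter), which is large. The remaining step, a 2.3-fold lower number from compound 1 to compound 2 (0.37 log units; beyond the scatter), is also modest. Among the compounds with values here, no measured compound carries the (isopropylcarbamoyl)methyl group, so these steps are only a loose guide. Removing the 2-amino-1,3-thiazol-5-yl group is expected to give a modest rise in this assay, an estimated 3.1-fold higher number from compound 3 to compound 4 (0.48 log units; beyond the scatter). For compound 4 the estimated half-life is 0.3 h, with an expected range of 0.1 h to 0.9 h.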

Compound 4, half-life: < 0.0667 h
Compound 4: no number, only a limit; the forecaster's own chance of this, stated with the estimate: 2%; at least 4.4-fold (0.65 log units) between middle value and limit.
By their numbers in this assay, from the lowest: compound 3; then compound 2; then compound 1. At a limit, below all of these: compound 4.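

Compound 4 gives only a limit, not a number, in this assay: the limit of < 0.0667 h in this assay, at which 1 of the 4 values shown sits.

At this saturated chain carbon, the ringless (isopropylcarbamoyl)methyl group gives an at least 8.2-fold lower number from compound 2 to compound 4 (0.91 log units; beyond the scatter) and an at least 19-fold lower number from compound 1 to compound 4 (1.28 log units; beyond the scatter), so the half-life here depends strongly on which group sits on this carbon. Against the 2-amino-1,3-thiazol-5-yl group it gives an at least 1.4-fold lower number from compound 3 to compound 4 (0.16 log units; that floor lies within the scatter), a floor that lies within the scatter, so that pair cannot be put in order.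

On these data alone, the true half-life of compound 4 remains unknown. Also open, as far as these compounds go, is whether a carboxylic acid or a simple amine on this carbon would match the triazole groups.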